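Replacing the benzothiazole group in compound 3

A few compounds are considered here, and "the series" means these few. Any claim that something is new, unique, unknown or untested is made for them only; others in the source may bear on it.

Values in a functional assay (blood) for inhibition, with Homo sapiens as the target; a higher number here means a weaker inhibitor, a lower number a stronger inhibitor:
- Compound 1 `CC(C)(C)Sc1c(CC(C)(C)C(=O)O)n(Cc2ccc(Cl)cc2)c2ccc(OCc3ccc4cc(F)c(F)cc4n3)cc12`: > 3000 nM (a limit)
- Compound 2 `CC(C)(C)Sc1c(CC(C)(C)C(=O)O)n(Cc2ccc(Cl)cc2)c2ccc(OCc3nc4cc(C(F)(F)F)ccc4s3)cc12`: > 3000 nM (a limit)
- Compound 3 `COc1ccc2nc(COc3ccc4c(c3)c(SC(C)(C)C)c(CC(C)(C)C(=O)O)n4Cc3ccc(Cl)cc3)sc2c1`: 670 nM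

Compound 3 is the only one of the three with a number rather than a limit. Compound 4 `C[C@@H](COc1ccc2c(c1)c(SC(C)(C)C)c(CC(C)(C)C(=O)O)n2Cc1ccc(Cl)cc1)c1ccccn1` carries 1-(pyridin-2-yl)ethyl in place of 6-methoxy-1,3-benzothiazol-2-yl, on a saturated chain carbon bound to an oxygen on an aromatic ring: 1-(pyridin-2-yl)ethyl in place of 6-methoxy-1,3-benzothiazol-2-yl on a saturated chain carbon bound to an oxygen on an aromatic ring. One measured step changes the group at this place, an at least 4.4-fold lower number from compound 1 to compound 3 (0.65 log units; beyond the scatter), and it shows that an exchange here can move the value beyond the scatter. Going by the values given here, a step of similar size is therefore expected in this assay, towards a higher number, since no measured compound in this set improves on the value of compound 3. The expected change is a 2.2-fold higher number from compound 3 to compound 4 (0.35 log units; beyond the scatter). For compound 4 the estimated value is 1500 nM, with an expected range of 450 nM to 5000 nM.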

Compound 4, half-maximal inhibitory concentration: 280 nM
Estimate against measurement, compound 4: 5.4-fold (0.73 log units) above, and the stated range ends above it.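

In this assay, 1-(pyridin-2-yl)ethyl in place of 6-methoxy-1,3-benzothiazol-2-yl gives a 2.4-fold lower number from compound 3 to compound 4 (0.38 log units; beyond the scatter), so this place accepts a smaller group with a single aromatic ring, and the two aromatic rings of the earlier groups are not required. The larger step is an at least 10-fold lower number from compound 1 to compound 4 (1.02 log units; beyond the scatter). Its size is only a lower bound, since the value of compound 1 is a limit: the limit of > 3000 nM in this assay, at which 2 of the 4 values shown sit.

Open, from the compounds shown here alone, is how the opposite stereoisomer, or a pyridin-2-ylmethyl group without the methyl, would read in this assay. Also open, going by these compounds, is the effect of an amine on the pyridine ring.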